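Methyl to hydrogen on an aromatic oxygen: series notes

The compounds below may be only part of what the source reports. "The series", "measured", "known", "first", "only" and "open" are said of these compounds alone.

Measured so far:
compound 1, `COc1cc(-c2nn(-c3cccc(NC(=O)Nc4cc(C(F)(F)F)cc(C(F)(F)F)c4)c3)cc2-c2ccncc2)ccc1Cl`, 1700 nM
compound 2, `COc1cc(-c2nn(-c3cccc(NC(=O)Nc4ccc(Cl)c(Cl)c4)c3)cc2-c2ccncc2)ccc1Cl`, 7320 nM
compound 3, `O=C(Nc1cccc(-n2cc(-c3ccncc3)c(-c3ccc(Cl)c(O)c3)n2)c1)Nc1ccc(Cl)c(Cl)c1`, 9850 nM

In a functional assay on SK-MEL-28 cells (Homo sapiens) for inhibition, read by sulforhodamine B assay, with a stated time of 48 h (a lower number here means a stronger inhibitor of growth, a higher number a weaker inhibitor of growth), compound 1 gives 1700 nM, the lowest of the three numbers; compound 2 gives 7320 nM and compound 3 gives 9850 nM, both beyond the scatter from compound 1. Compound 1 and compound 2 differ in more than one place, and the difference between the two cores is not broken down here. Compound 2 and compound 3 differ in one place: hydrogen in place of methyl on an oxygen on an aromatic ring. That step read a 1.3-fold higher number from compound 2 to compound 3 (0.13 log units; within the scatter).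

Compound 4, `O=C(Nc1cccc(-n2cc(-c3ccncc3)c(-c3ccc(Cl)c(O)c3)n2)c1)Nc1cc(C(F)(F)F)cc(C(F)(F)F)c1`, is not yet measured in this assay. Going by the values given here, it differs from compound 1 by hydrogen in place of methyl on an oxygen on an aromatic ring, the same change at the same place as between compound 2 and compound 3, and no other measured pair in the set shows this change. The expectation for compound 4 rests on one measured pair, so it is held loosely. Compound 4 is expected to stay close to compound 1, because a 1.3-fold higher number from compound 2 to compound 3 (0.13 log units; within the scatter) lay within the scatter. The step from compound 1 to compound 4 is expected to be a 1.3-fold higher number from compound 1 to compound 4 (0.11 log units; within the scatter). For compound 4 the estimate in this assay is 2200 nM, expected between 1000 nM and 5000 nM.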

Compound 4, concentration for total growth inhibition: 1570 nM
For compound 4 the middle estimate is 1.4-fold (0.15 log units) above the measured one; the range from low to high includes it.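

In this assay, the methoxy to hydroxy change reads a 1.1-fold lower number from compound 1 to compound 4 (0.03 log units; within the scatter), so on this second core it again leaves the number within the scatter. The change therefore carries from one core to the other in this series without a readable difference between the two steps: the same change on two cores in this assay, a 1.3-fold higher number (0.13 log units; within the scatter) from compound 2 to compound 3 and a 1.1-fold lower number (0.03 log units; within the scatter) from compound 1 to compound 4, 1.5-fold (0.16 log units) apart, within the scatter of two such steps This rests on just two pairs, both read in this assay and both made at the 4-chloro-3-methoxyphenyl group, so it does not show that methoxy and hydroxy are interchangeable on other cores or in other cell lines, and it gives no reason for the agreement.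

Still open, from the compounds shown here alone, is whether a longer chain on that oxygen, such as an ethyl group, would stay as close as hydrogen and methyl do here. Also open, going by these compounds, is whether an amine or a carboxylic acid in place of the hydroxy group would hold the number in the same range.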